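Aryl swap on the imine carbon: chloro for methoxy

The source may report more compounds than this note shows. Statements on the series, on what has been measured and on what is new or still open speak of the compounds shown alone.

Two analogues of this core have been measured. Compound 1 `S=C(Nc1ccccc1)N1N=C(c2ccc(Br)cc2)CC1c1ccc2c(c1)OCCO2` gives 32100 nM in a functional assay on HCT-116 cells (Homo sapiens) for antiproliferative activity, read by MTT assay, with a stated time of 48 h; a higher number here means a weaker inhibitor of growth, a lower number a stronger inhibitor of growth. Compound 2 `COc1ccccc1C1=NN(C(=S)Nc2ccccc2)C(c2ccc3c(c2)OCCO3)C1` reaches only the limit of this assay, > 200000 nM, so for compound 2 there is no number, just a limit. Among the measured compounds shown here, the one measured step, an at least 6.2-fold higher number from compound 1 to compound 2 (0.79 log units; beyond the scatter), thus rests on that limit, as recorded in the limit of > 200000 nM in this assay, at which 1 of the 2 values shown sits.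

Compound 3 `S=C(Nc1ccccc1)N1N=C(c2cccc(Cl)c2)CC1c1ccc2c(c1)OCCO2` is the next member. Its change from compound 2 is 3-chlorophenyl in place of 2-methoxyphenyl on a carbon with a double bond to nitrogen. For the measured compounds named here, the only step that bears on this is the one from compound 1 to compound 2, in which a halophenyl was replaced by 2-methoxyphenyl and the number rose beyond the scatter to the limit. Compound 3 moves back to a halophenyl, though with chlorine at a different position of the ring than the bromine of compound 1, so a return toward the range of compound 1 is expected, but with wide uncertainty. The expected step is an at least 4.0-fold lower number from compound 2 to compound 3 (0.60 log units; beyond the scatter), downward. For compound 3 the estimate in this assay is 50000 nM, within 15000 nM to 200000 nM.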

Compound 3, concentration for 50% growth inhibition: 138000 nM
Compound 3: the middle estimate sits 2.8-fold (0.44 log units) below what was measured, within the range that was stated.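

In this assay, 3-chlorophenyl in place of 4-bromophenyl gives a 4.3-fold higher number from compound 1 to compound 3 (0.63 log units; beyond the scatter), so carrying a halogen on the phenyl at the carbon with a double bond to nitrogen does not by itself keep the number of compound 1. The other comparison reads an at least 1.4-fold lower number from compound 2 to compound 3 (0.16 log units; that floor lies within the scatter), so on these data 3-chlorophenyl is not separated from 2-methoxyphenyl at this position, and the new value sits much closer to the top of the measurable range than the value of compound 1 does. That step gives only a floor, since compound 2 has no number, just a limit of the assay: the limit of > 200000 nM in this assay, at which 1 of the 3 values shown sits.

Between compound 1 and compound 3 both the halogen and its place on the phenyl ring differ, so the compounds shown leave open which of the two goes with the higher number. Also open, on these data alone, is how this position reads with an unsubstituted phenyl, a pyridyl ring or a phenyl carrying an amine or a carboxylic acid.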